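Naphthalen-2-yl for phenoxyethyl: an expected gain in potency

The source may report more compounds than this note shows. Statements on the series, on what has been measured and on what is new or still open speak of the compounds shown alone.

In an in vitro functional assay on CHO cells for antagonist activity at prostaglandin E2 receptor EP3 subtype (Mus musculus) (on this read-out higher numbers stand for weaker inhibition and lower numbers for stronger inhibition), compound 3 `O=C(O)/C=C/c1ccc(Cn2ccnc2)cc1OCCCCOc1ccccc1` gives 3500 nM. That number sits at the high end of the three measured: compound 2 `O=C(O)/C=C/c1ccc(Cn2ccnc2)cc1OCCCOc1ccccc1` gives 3000 nM, and a 1.2-fold higher number from compound 2 to compound 3 (0.07 log units; within the scatter). Compound 1 `O=C(O)/C=C/c1ccc(Cn2cccn2)cc1OCCc1ccc2ccccc2c1` gives 73 nM, a much lower number, though it differs from compound 3 in more than one place, so no single step can be read from that pair. Compound 4 `O=C(O)/C=C/c1ccc(Cn2ccnc2)cc1OCCc1ccc2ccccc2c1` has not yet been measured; it differs from compound 3 by naphthalen-2-yl in place of 2-phenoxyethyl on a saturated chain carbon, two bonds along the chain from an oxygen on an aromatic ring. Within the data shown here, the only measured step, the chain lengthening from compound 2 to compound 3, changed nothing beyond the scatter and bears little on this larger exchange. Compound 4 shares its naphthalen-2-yl group with compound 1, though the two differ elsewhere in the shared core, and compound 1 gives 73 nM. On that basis compound 4 is expected to show a large drop in number, an 18-fold lower number from compound 3 to compound 4 (1.24 log units; beyond the scatter), and its estimated value in this assay is 200 nM, with a range from 50 nM to 1000 nM.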

Compound 4, half-maximal inhibitory concentration: 50 nM
Beside the measured number, compound 4's estimate is 4.0-fold (0.60 log units) above it; the range from low to high includes it.
By their numbers in this assay, from the lowest: compounds 4 and 1 (each within the scatter of the next); then compounds 2 and 3 (each within the scatter of the next).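

In this assay, among these compounds, naphthalen-2-yl on a saturated chain carbon, two bonds along the chain from an oxygen on an aromatic ring, produces the first change beyond the scatter among the steps at this place: a 70-fold lower number from compound 3 to compound 4 (1.85 log units; beyond the scatter) and, with phenoxymethyl as the group replaced, a 60-fold lower number from compound 2 to compound 4 (1.78 log units; beyond the scatter). The other change, 1H-imidazol-1-yl in place of 1H-pyrazol-1-yl on a saturated chain carbon bound to an aromatic carbon, gives a 1.5-fold lower number from compound 1 to compound 4 (0.16 log units; within the scatter), so the low numbers stay with naphthalen-2-yl under either of these groups. Nothing available explains the size of this step.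

The exchange alters the ring count and removes the chain oxygen at once, and the compounds shown do not separate these two changes. They also leave open how a plain phenyl or a naphthalen-1-yl group would read at this place.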